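The source may hold more compounds than are shown below. What is called first, only, known or untested is meant among the compounds shown, and "the series" means these compounds.

Measured compounds in an ADME assay on Vero cells (Chlorocebus sabaeus) for cytotoxicity, read by neutral red uptake, tested at 49 ug/mL; on this read-out higher numbers stand for a weaker effect at the one concentration tested and lower numbers for a stronger effect:
Compound 1, `O=C1CSC(c2ccc(F)cc2)N1CCN1CCCCC1`: 100%
Compound 2, `O=C1CSC(c2ccccc2Cl)N1CCN1CCCCC1`: 100%
Compound 3, `COc1cccc(C2SCC(=O)N2CCN2CCCCC2)c1`: 90%

The three compounds share one core and differ only in the aromatic group attached to a saturated ring carbon. Compound 3 stands with 90% at a number that differs from compound 1 and from compound 2 by no more than the usual scatter, so the three read-outs are not distinguishable. For the measured compounds named here, the one measured step, no change at the digits printed from compound 1 to compound 2 (within the scatter), exchanged the aromatic group itself and left the read-out unchanged within the scatter.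

Compound 4, `O=C1CSC(c2cccc(O)c2)N1CCN1CCCCC1`, has not yet been measured. It differs from compound 3 by hydrogen in place of methyl on an oxygen on an aromatic ring. Going by the values given here, no measured step touches an oxygen substituent on the aromatic ring; the only step available concerns a different part of that ring and was flat. On that basis the step of a number 5 percentage points higher from compound 3 to compound 4 (within the scatter) is expected to stay within the scatter. Compound 4 is therefore estimated at 95% in this assay. Its range is expected to run from 80% to 100%.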

Compound 4, a percentage reported as activity, at one concentration (the size of the read-out at that concentration, not a potency): 100%
For compound 4 the middle estimate is 5 percentage points below the measured one; low and high end bracket the measured number.
By their numbers in this assay, from the lowest: compounds 3, 1, 2 and 4 (each within the scatter of the next).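

In this assay, the change of methoxy to hydroxy on an oxygen on an aromatic ring gives a number 10 percentage points higher from compound 3 to compound 4 (within the scatter), so this read-out does not separate the two groups at this place. The 3-hydroxyphenyl group also gives no change at the digits printed from compound 2 to compound 4 (within the scatter) and no change at the digits printed from compound 1 to compound 4 (within the scatter), which extends the absence of any change beyond the scatter to an aromatic group carrying a free hydroxy. No measurement at hand explains this result.

From the compounds shown here alone, whether an amine or a carboxylic acid on the aromatic ring, or a longer chain such as ethoxy on that oxygen, would take this assay beyond the scatter remains open. The same question stands for changes to the shared core away from the aromatic group.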